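The compounds below may be only part of what the source reports. "The series", "measured", "known", "first", "only" and "open" are said of these compounds alone.

Compound 1 `COc1ccc(N/C=C\C(=O)c2cn(-c3ccccc3)nc2-c2ccccc2)cc1` — in an ADME assay on HaCaT cells (Homo sapiens) for antiproliferative activity, read by MTT assay, with a stated time of 48 h (on this read-out higher numbers stand for weaker inhibition and lower numbers for stronger inhibition), compound 1 reaches only the limit > 50000 nM.
Compound 2 `O=C(/C=C\Nc1ccc(C(F)(F)F)cc1)c1cn(-c2ccccc2)nc1-c1ccc(F)cc1` — compound 2 likewise reaches only the limit > 50000 nM.
Compound 3 `O=C(/C=C\Nc1ccc(O)cc1)c1cn(-c2ccccc2)nc1-c1ccc(F)cc1` — compound 3 gives 16300 nM.

Among the measured compounds shown here, compound 3 is thus the one compound with a measured number; the other two values are limits of the assay, as the limit of > 50000 nM in this assay, at which 2 of the 3 values shown sit, states. For the measured compounds named here, the single measured step is an at least 3.0-fold lower number from compound 2 to compound 3 (0.48 log units; beyond the scatter), a hydroxy in place of a trifluoromethyl on the aromatic carbon of the anilino ring, which moved the number from the limit into the measured range.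

Compound 4 `COc1ccc(N/C=C\C(=O)c2cn(-c3ccccc3)nc2-c2ccc(F)cc2)cc1` differs from compound 3 by methyl in place of hydrogen on an oxygen on an aromatic ring. Going by the values given here, no measured step describes methylation of this hydroxy group directly. Compound 1 carries the same 4-methoxyphenyl amino group on a core without fluorine and sits at the limit, so the methoxy analogues seen so far have not given a number. Given that compound 3 only just yielded a value, a weakening is expected for compound 4 of a 2.8-fold higher number from compound 3 to compound 4 (0.44 log units; beyond the scatter), likely taking it back toward the limit. The estimate for compound 4 is 45000 nM, within 15000 nM to 150000 nM.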

Compound 4, half-maximal inhibitory concentration: 19600 nM
Compound 4: the middle estimate sits 2.3-fold (0.36 log units) above what was measured; measured number inside the range.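

In this assay, the hydrogen on this oxygen can be replaced by methyl without a readable change, a 1.2-fold higher number from compound 3 to compound 4 (0.08 log units; within the scatter), so the free hydroxy is not required for a measured number at this position. The methoxy group on the fluorinated core thus gives a number too, and its gain over trifluoromethyl on the same aromatic carbon, an at least 2.5-fold lower number from compound 2 to compound 4 (0.40 log units; beyond the scatter), runs in the same direction as that of hydroxy, an at least 3.0-fold lower number from compound 2 to compound 3 (0.48 log units; beyond the scatter). The methoxy pair also shows that the core matters and not only the group on this oxygen, with an at least 2.5-fold lower number from compound 1 to compound 4 (0.40 log units; beyond the scatter) for fluoro in place of hydrogen on an aromatic carbon, though this step and the step from compound 2 both start from a limit and not from a number: the limit of > 50000 nM in this assay, at which 2 of the 4 values shown sit.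

The compounds shown leave open whether a longer chain on this oxygen, such as ethoxy, or an amine in place of the hydroxy would keep a number in this range. They also leave open whether fluoro in place of hydrogen does the same with a group other than (4-methoxyphenyl)amino, and how large that step really is.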